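Propyl for Isopropyl on the Side Chain of Two Cores

The source may report more compounds than this note shows. Statements on the series, on what has been measured and on what is new or still open speak of the compounds shown alone.

Compound 1, `COc1cc2ncnc(N3CCc4ccccc43)c2cc1NC(=O)/C=C/C(C)C`: 6410 nM
Compound 2, `CCC/C=C/C(=O)Nc1cc2c(N3CCc4ccccc43)ncnc2cc1OC`: 2920 nM
Compound 3, `CC(C)/C=C/C(=O)Nc1cc2c(N3CCc4ccccc43)ncnc2cc1O[C@@H]1CCOC1`: 8520 nM

Three compounds were tested in a functional assay on A549 cells (Homo sapiens) for antiproliferative activity, read by MTT assay, with a stated time of 72 h; on this read-out lower numbers stand for stronger inhibition and higher numbers for weaker inhibition. Compound 1 gives 6410 nM in this assay, compound 2 gives 2920 nM, and compound 3 gives 8520 nM. Compound 2 differs from compound 1 by one change, (propyl in place of isopropyl on a double-bonded chain carbon bound to a double-bonded chain carbon), and this change brought a 2.2-fold lower number from compound 1 to compound 2 (0.34 log units; beyond the scatter). Compound 3 differs from compound 1 at another place, (oxolan-3-yl in place of methyl on an oxygen on an aromatic ring), and that change gave a 1.3-fold higher number from compound 1 to compound 3 (0.12 log units; within the scatter), a step that stays within the scatter of the measurement.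

Compound 4, `CCC/C=C/C(=O)Nc1cc2c(N3CCc4ccccc43)ncnc2cc1O[C@@H]1CCOC1`, has not yet been measured in this assay. It differs from compound 3 by propyl in place of isopropyl on a double-bonded chain carbon bound to a double-bonded chain carbon. Among the measured compounds shown here, this is the same change as the one from compound 1 to compound 2: the groups that leave and enter and the place they occupy are described in the same words. The two cores differ only in the way told by oxolan-3-yl in place of methyl on an oxygen on an aromatic ring. Since the step from compound 1 to compound 2 was modest but beyond the scatter, a step of similar size, a 2.2-fold lower number from compound 3 to compound 4 (0.34 log units; beyond the scatter), is expected for compound 4 from compound 3, because a 2.2-fold lower number from compound 1 to compound 2 (0.34 log units; beyond the scatter) was seen on the other core. On that basis compound 4 is estimated at 3900 nM in this assay, with a range expected between 1800 nM and 8500 nM.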

Compound 4, half-maximal inhibitory concentration: 9110 nM
Compound 4: middle estimate off by 2.3-fold (0.37 log units), on the low side; measured number outside the range, above it.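

Carried onto the core of compound 3, the change from isopropyl to propyl gave a 1.1-fold higher number from compound 3 to compound 4 (0.03 log units; within the scatter) in this assay, so the modest step seen on the core of compound 1 did not recur as a step beyond the scatter, yet the two steps cannot be told apart: the same change on two cores in this assay, a 2.2-fold lower number (0.34 log units; beyond the scatter) from compound 1 to compound 2 and a 1.1-fold higher number (0.03 log units; within the scatter) from compound 3 to compound 4, 2.3-fold (0.37 log units) apart, within the scatter of two such steps

Read the other way, oxolan-3-yl in place of methyl gave a 3.1-fold higher number from compound 2 to compound 4 (0.49 log units; beyond the scatter), a step beyond the scatter on the propyl pair but within it on the isopropyl pair, and again the two do not separate: the same change on two cores in this assay, a 1.3-fold higher number (0.12 log units; within the scatter) from compound 1 to compound 3 and a 3.1-fold higher number (0.49 log units; beyond the scatter) from compound 2 to compound 4, 2.3-fold (0.37 log units) apart, within the scatter of two such steps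

The four compounds therefore show that the lower number seen on the first core did not clearly repeat on the second, but they do not show that the core alters the effect of the change, since a single pair on each core fits both a step that carries over and one that does not.

The compounds shown leave open how a butyl or cyclopropyl group on a double-bonded chain carbon would behave on these two cores. They also leave open whether a group other than methyl or oxolan-3-yl on the oxygen, such as ethyl or piperidin-4-yl, would give the same picture.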